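Acrylamide chain variation on a shared quinazoline-type series

The source may report more compounds than this note shows. Statements on the series, on what has been measured and on what is new or still open speak of the compounds shown alone.

Working notes on a small set sharing one core. Compound 1 `CC(C)/C=C/C(=O)Nc1cc2c(N3CCc4ccccc43)ncnc2cc1O[C@@H]1CCOC1` and compound 2 `CC(C)=CC(=O)Nc1cc2c(N3CCCc4ccccc43)ncnc2cc1O[C@@H]1CCOC1` have both been measured in a functional assay on PC-3 cells (Homo sapiens) for antiproliferative activity, read by MTT assay, with a stated time of 72 h; on this read-out higher numbers stand for weaker inhibition and lower numbers for stronger inhibition. In this assay compound 1 gives 11200 nM, and compound 2 gives 9020 nM; the two numbers lie within the scatter of each other, so no order between them can be read, and compound 2 simply holds the lower of the two numbers shown. Among the compounds with values here, no single-point step between measured compounds is available, since compound 1 and compound 2 differ in more than one place.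

The next compound, compound 3 `CC(C)/C=C/C(=O)Nc1cc2c(N3CCCc4ccccc43)ncnc2cc1O[C@@H]1CCOC1`, is not yet measured. Relative to compound 2 the change is 3-methylbut-1-en-1-yl in place of 2-methylprop-1-en-1-yl on a carbonyl carbon, in words 3-methylbut-1-en-1-yl in place of 2-methylprop-1-en-1-yl on a carbonyl carbon. The measured compounds give no direct guide to this change, so the expectation in this assay is a step within the scatter, with no clear direction. Compound 3 is therefore expected to give 10000 nM, with a range from 4000 nM to 25000 nM, an estimated step of a 1.1-fold higher number from compound 2 to compound 3 (0.04 log units; within the scatter).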

Compound 3, half-maximal inhibitory concentration: 8510 nM
The estimate for compound 3 lay 1.2-fold (0.07 log units) above the measured number; the measured number falls inside the stated range.
By their numbers in this assay, from the lowest: compounds 3, 2 and 1 (each within the scatter of the next).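

Within the data shown here, on the carbonyl carbon, 3-methylbut-1-en-1-yl in place of 2-methylprop-1-en-1-yl gives, in this assay, a 1.1-fold lower number from compound 2 to compound 3 (0.03 log units; within the scatter), the first single-place reading at this position: going from a chain of 4 heavy atoms to one of 5 with the double bond kept produces no difference that can be told from the scatter. With the 3-methylbut-1-en-1-yl chain held constant, 1,2,3,4-tetrahydroquinolin-1-yl in place of 2,3-dihydro-1H-indol-1-yl on an aromatic carbon gives a 1.3-fold lower number from compound 1 to compound 3 (0.12 log units; within the scatter), also within the scatter, so neither single change separates these compounds in this assay. No measurement shown here bears on the reason for either result.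

From the compounds shown here alone, it remains open whether a group of a different kind on the carbonyl carbon, such as a chain ending in a dimethylamine or a carboxylic acid, or a much longer alkenyl chain, would move the number in this assay beyond the scatter. Going by these compounds, it is equally open whether an open-chain amine on the aromatic carbon, in place of 1,2,3,4-tetrahydroquinolin-1-yl, would do so.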